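Chain shortening with a terminal hydroxy: estimate for compound 4

This account rests on a few compounds, and the source may have more. Where it says the series, first, only, none or still open, it means among the compounds named here.

Compound 1 `CCCCn1nc2ccccc2c1OC` gives 910 nM in an assay on isolated protein (urine) for inhibition of Myeloperoxidase (Homo sapiens), read by spectrophotometry; on this read-out higher numbers stand for weaker inhibition and lower numbers for stronger inhibition.
Compound 2 `CCCCCCCCn1nc2ccccc2c1OC` gives only a limit, > 10000 nM.
Compound 3 `CCCCCCCCn1nc2ccccc2c1OCC` gives only a limit, > 10000 nM.

Compound 2 stands at the limit of > 10000 nM in this assay, at which 2 of the 3 values shown sit, so its value is a limit and not a number, and the series fixes its position only from one side. Within the data shown here, the single readable step is an at least 10-fold higher number from compound 1 to compound 2 (1.04 log units; beyond the scatter), where butyl added at the end of the chain on the nitrogen moved the value out of the measurable range. The step that the two limits leave unreadable from compound 2 to compound 3 cannot be read, both of its ends being limits.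

Compound 4 `COc1c2ccccc2nn1CCCCCO` differs from compound 2 by hydroxy in place of propyl on a saturated chain carbon, five bonds along the chain from an aromatic nitrogen. Among the measured compounds shown here, this removes three of the chain carbons whose addition was measured in the step from compound 1 to compound 2, but leaves a chain one carbon longer than butyl and adds a hydroxy, for which no measured step exists. The expectation is therefore a move back toward the number of compound 1 without fully reaching it: the estimated step is an at least 3.3-fold lower number from compound 2 to compound 4 (0.52 log units; beyond the scatter). Compound 4 is expected at about 3000 nM, within a range from 800 nM to 12000 nM, with a real chance that the assay again returns only a limit.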

Compound 4, half-maximal inhibitory concentration: 1540 nM
For compound 4 the middle estimate is 1.9-fold (0.29 log units) above the measured one; the measured number falls inside the stated range.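

In this assay, hydroxy in place of propyl on a saturated chain carbon, five bonds along the chain from an aromatic nitrogen, returns the series to a measurable number, giving an at least 6.4-fold lower number from compound 2 to compound 4 (0.81 log units; beyond the scatter). This step is readable from one side only, and its true size may be larger: the limit of > 10000 nM in this assay, at which 2 of the 4 values shown sit. Adding hydroxymethyl to the chain of compound 1 gives a 1.7-fold higher number from compound 1 to compound 4 (0.23 log units; within the scatter), so this added group does not separate the two compounds in this assay, unlike the butyl addition in the step to compound 2.

The compounds shown do not separate the loss of chain carbons from the gain of hydroxy, and it remains open whether a plain pentyl chain, or an amine or a carboxylic acid at the end of the same chain, would read like compound 4. On these data alone, the step between compound 2 and compound 3 cannot be read, both ends being limits, so the effect of ethoxy against methoxy on the shared core also remains open.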